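Isopropoxy for methoxy on a second quinoline-type core

The source may report more compounds than this note shows. Statements on the series, on what has been measured and on what is new or still open speak of the compounds shown alone.

Measured so far:
- compound 1, `COc1cc(-c2ccc(O)c(O)c2)nc2ccccc12`, in a functional assay on HT-22 cells (Mus musculus), read by MTT assay, with a stated time of 24 h; on this read-out higher numbers stand for an effect only at larger amounts of compound and lower numbers for an effect already at smaller amounts: 40 nM
- compound 2, `CC(C)Oc1cc(-c2ccc(O)c(O)c2)nc2ccccc12`, in this assay: 20 nM
- compound 3, `COc1cc(-c2ccc(N(C)C)cc2)nc2ccccc12`, in this assay: 60 nM

Compound 1 and compound 2 share a core and differ only at one spot, as given by isopropyl in place of methyl on an oxygen on an aromatic ring. That change gave a 2.0-fold lower number from compound 1 to compound 2 (0.30 log units; within the scatter). Compound 3 carries a different core; the difference between the two cores is not broken down here. In this assay compound 3 stands at the highest of the three numbers, within the scatter of compound 1 and beyond it only against compound 2.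

Compound 4, `CC(C)Oc1cc(-c2ccc(N(C)C)cc2)nc2ccccc12`, is not yet measured. For the measured compounds named here, it differs from compound 3 by isopropyl in place of methyl on an oxygen on an aromatic ring, which is the same change as the one from compound 1 to compound 2, at a place described in the same words. Going by the values given here, the expectation for compound 4 is therefore a step of about a 2.0-fold lower number from compound 3 to compound 4 (0.30 log units; within the scatter), resting on the single earlier step of a 2.0-fold lower number from compound 1 to compound 2 (0.30 log units; within the scatter) and on nothing more, since only one such pair exists. Compound 4 is thus estimated at 30 nM, with a likely range from 15 nM to 60 nM.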

Compound 4, half-maximal effective concentration: 50 nM
Estimate against measurement, compound 4: 1.7-fold (0.22 log units) below; low and high end bracket the measured number.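

In this assay, putting isopropoxy in place of methoxy on the core of compound 3 gave a 1.2-fold lower number from compound 3 to compound 4 (0.08 log units; within the scatter) and so a step no larger than the usual scatter of repeated measurements. Set beside the earlier case, the two steps do not differ by more than that scatter allows: the same change on two cores in this assay, a 2.0-fold lower number (0.30 log units; within the scatter) from compound 1 to compound 2 and a 1.2-fold lower number (0.08 log units; within the scatter) from compound 3 to compound 4, 1.7-fold (0.22 log units) apart, within the scatter of two such steps. This shows that, on these two cores, nothing separates the behaviour of the change, but it does not show that the change has a real effect on either core, and two pairs are too few to say that it would carry over to other cores in the series.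

The compounds shown carry only methoxy and isopropoxy on this oxygen, so it stays open how a longer chain, a cyclopropyl ring or a chain ending in an amine would read in this assay here. Also open, going by these compounds, is whether the step would look the same on a core with neither the two hydroxyl groups of compound 1 nor the dimethylamino group of compound 3.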